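Swapping a Saturated Ring for an Aromatic One

The source may report more compounds than this note shows. Statements on the series, on what has been measured and on what is new or still open speak of the compounds shown alone.

Compound 2 `CC(C)C(c1ccc(-c2ccc3cccc(F)c3c2)[nH]c1=O)N1CCNC1=O` gives 9.1 nM in an assay on CHO cells for displacement of a labelled ligand from prostaglandin E2 receptor EP3 subtype (Homo sapiens), read by radioligand binding (a lower number here means a stronger inhibitor, a higher number a weaker inhibitor), the lower of the two numbers recorded so far. Compound 1 `CCn1ncc2c(F)cc(-c3ccc(C(CC)(CC)c4nnc(C)[nH]4)c(=O)[nH]3)cc21` gives 34 nM in this assay, a gap beyond the usual scatter of this kind of measurement. Compound 3 `Cc1nc(C(c2ccc(-c3ccc4cccc(F)c4c3)[nH]c2=O)C(C)C)[nH]c1C` differs from compound 2 in one place: 4,5-dimethyl-1H-imidazol-2-yl in place of 2-oxoimidazolidin-1-yl on a saturated chain carbon bound to an aromatic carbon and a saturated chain carbon. Among the compounds with values here, no step between measured compounds is known, so this change has no precedent here. A modest rise in the number is expected, a step of a 2.2-fold higher number from compound 2 to compound 3 (0.34 log units; beyond the scatter) in size. Compound 3 is therefore estimated at 20 nM in this assay, within a range from 6 nM to 70 nM.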

Compound 3, inhibition constant: 7 nM
For compound 3 the middle estimate is 2.9-fold (0.46 log units) above the measured one; the measured number falls inside the stated range.
By their numbers in this assay, from the lowest: compounds 3 and 2 (each within the scatter of the next); then compound 1.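

In this assay the change at the saturated chain carbon bound to an aromatic carbon and a saturated chain carbon gives a 1.3-fold lower number from compound 2 to compound 3 (0.11 log units; within the scatter) and stays within the scatter. For this pair, then, an aromatic five-membered ring serves this position as well as a non-aromatic one, with the two compounds indistinguishable in this measurement. Nothing available explains this outcome.

The compounds shown leave open whether the two methyl groups of the new ring matter, as an imidazole without them is not among them. They also leave open whether an open-chain group, such as an amine or a carboxylic acid, could replace the ring.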